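A few compounds are considered here, and "the series" means these few. Any claim that something is new, unique, unknown or untested is made for them only; others in the source may bear on it.

Measured so far in an assay on membranes from lung (Cavia porcellus) for binding affinity to cysteinyl leukotriene receptor (Homo sapiens); a higher number here means a weaker inhibitor, a lower number a stronger inhibitor:
compound 1 `CC(CCc1cccc(OCc2ccc3ccccc3n2)c1)Cc1nnn[nH]1`, 17 nM
compound 2 `O=C(O)CC1CCCC1Cc1ccc(OCc2ccc3ccccc3n2)cc1`, 100 nM
compound 3 `O=C(O)CCCCc1cccc(OCc2ccc3ccccc3n2)c1`, 100 nM

Compound 2 and compound 3 stand level at the digits shown and together hold the highest numbers of the three in this assay; compound 1 holds the lowest number of the set. For the measured compounds named here, the only measured single-point step is a 5.9-fold higher number from compound 1 to compound 3 (0.77 log units; beyond the scatter), in which 2-carboxyethyl takes the place of 1-((1H-tetrazol-5-yl)methyl)ethyl and the number rises.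

Compound 4 `CC(CCc1nnn[nH]1)Cc1ccc(OCc2ccc3ccccc3n2)cc1` differs from compound 2 by 3-(1H-tetrazol-5-yl)-1-methylpropyl in place of 2-(carboxymethyl)cyclopentyl on a saturated chain carbon bound to an aromatic carbon. The exchange runs in the opposite sense to the measured step: a carboxylic acid on a saturated carbon framework leaves and a tetrazole on a short chain enters, although the chain that carries the tetrazole and the point where it joins the shared core are not identical to those in compound 1. Going by the values given here, the step from compound 1 to compound 3 is the only guide, and it was of modest size beyond the scatter. The step in this assay is therefore expected to be downward and of about that size, with the range widened for the differences in the chain. Compound 4 is expected at 25 nM, between 8 nM and 80 nM. The expected step is a 4.0-fold lower number from compound 2 to compound 4 (0.60 log units; beyond the scatter).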

Compound 4, inhibition constant: 12 nM
Estimate against measurement, compound 4: 2.1-fold (0.32 log units) above; the measured number falls inside the stated range.
By their numbers in this assay, from the lowest: compounds 4 and 1 (each within the scatter of the next); then compounds 2 and 3 (each within the scatter of the next).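

In this assay, placing 3-(1H-tetrazol-5-yl)-1-methylpropyl in place of 2-(carboxymethyl)cyclopentyl on a saturated chain carbon bound to an aromatic carbon gives an 8.3-fold lower number from compound 2 to compound 4 (0.92 log units; beyond the scatter) and is a second exchange of a carboxylic acid group for a tetrazole group, here at equal heavy-atom count and with the five-membered non-aromatic ring lost. Together with a 5.9-fold higher number from compound 1 to compound 3 (0.77 log units; beyond the scatter) as the earlier step, the tetrazole-bearing member holds the lower number in both readable pairs, and neither pair goes against this, though two pairs on differing chains make a narrow base. Nothing shown gives a reason for the direction or size of the new step.

The new step changes the acidic-end group's identity and the carbon framework together, so the compounds shown do not divide it between the tetrazole and the loss of the cyclopentyl ring. Still open, from the compounds shown here alone, are a carboxylic acid on the open 1-methylpropyl chain of compound 4, a 1H-tetrazol-5-yl group on the cyclopentyl framework of compound 2, and a longer chain carrying the tetrazole.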